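A few compounds are considered here, and "the series" means these few. Any claim that something is new, unique, unknown or untested is made for them only; others in the source may bear on it.

Measured compounds:
- compound 1, `CC(C)[C@H](NC(=O)COc1cccc2ccccc12)C(=O)N[C@@H](CC(=O)O)C(=O)COc1ccccc1`, 14000 nM
- compound 2, `CC(C)[C@H](NC(=O)COc1cccc2ccccc12)C(=O)N[C@@H](CC(=O)O)C(=O)COc1ccc(OC(F)(F)F)cc1`, 29100 nM

In a functional assay on Jurkat cells (Homo sapiens) (a higher number here means a weaker inhibitor, a lower number a stronger inhibitor), compound 1 gives the lower of the two numbers, so it is the stronger inhibitor of the pair; compound 2 differs by a trifluoromethoxy in place of hydrogen on an aromatic carbon and gives a 2.1-fold higher number from compound 1 to compound 2 (0.32 log units; beyond the scatter). Compound 3, `CC(C)[C@H](NC(=O)COc1cccc2ccccc12)C(=O)N[C@@H](CC(=O)O)C(=O)COc1cc(F)ccc1F`, keeps the shared core of compound 1 and changes only the group on an oxygen on a saturated carbon: 2,5-difluorophenyl in place of phenyl on an oxygen on a saturated carbon.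

Among the compounds with values here, only the step from compound 1 to compound 2 bears on this change, since it also alters the phenyl on that oxygen, and it was modest. Within the data shown here, no measured step adds fluorine on its own, so the expectation rests loosely on that one step: a small rise, a 1.2-fold higher number from compound 1 to compound 3 (0.08 log units; within the scatter), possibly within the scatter. Compound 3 is therefore estimated at 17000 nM, with a range from 7500 nM to 38000 nM.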

Compound 3, half-maximal inhibitory concentration: > 100000 nM
Compound 3 gave a limit, no number; the forecaster's own chance of this, stated with the estimate: 10%; at least 5.8-fold (0.76 log units) between middle value and limit.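

The reading for compound 3 in this assay is a limit of the assay and not a number: the limit of > 100000 nM in this assay, at which 1 of the 3 values shown sits. Even so, it shows that this position is sensitive to the ring on the oxygen: putting 2,5-difluorophenyl in place of phenyl gives an at least 7.1-fold higher number from compound 1 to compound 3 (0.85 log units; beyond the scatter), so two fluorine atoms are enough to move the result well beyond the scatter. Substituted rings here also do not all behave alike, as 2,5-difluorophenyl in place of 4-(trifluoromethoxy)phenyl gives an at least 3.4-fold higher number from compound 2 to compound 3 (0.53 log units; beyond the scatter).

Going by these compounds, whether a single fluorine would produce the same loss, and which of the two fluorines matters more, remains open. It is also unknown how a ring carrying an amine or a carboxylic acid would read, and the true size of both steps stays hidden behind the limit.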